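Methoxy to chloro in a flat set of amides

A few compounds are considered here, and "the series" means these few. Any claim that something is new, unique, unknown or untested is made for them only; others in the source may bear on it.

compound 1 `NC(=O)c1c(NC(=O)C2CC2)sc2c1CCCC2` gives 1200 nM
compound 2 `NC(=O)c1c(NC(=O)c2ccco2)sc2c1CCCC2` gives 1500 nM
compound 3 `COc1ccc(C(=O)Nc2sc3c(c2C(N)=O)CCCC3)cc1` gives 1300 nM

All three values come from a functional assay on MV4-11 cells (Homo sapiens) for antiproliferative activity (on this read-out lower numbers stand for stronger inhibition and higher numbers for weaker inhibition), and lie within the scatter of one another, so compound 3 stands level with compound 1 and compound 2. Compound 4 `NC(=O)c1c(NC(=O)c2ccc(Cl)cc2)sc2c1CCCC2` carries chloro in place of methoxy on an aromatic carbon, para to a large group (in full: chloro in place of methoxy on an aromatic carbon). Going by the values given here, no measured step touches this position. Among the compounds with values here, the only measured step (a 1.3-fold higher number from compound 1 to compound 2 (0.10 log units; within the scatter)) swaps the group on a carbonyl carbon and stays within the scatter, so it offers indirect guidance at best. No step beyond the scatter is therefore expected in this assay (expected: a 1.1-fold lower number from compound 3 to compound 4 (0.03 log units; within the scatter)). The estimate for compound 4 is 1200 nM with an expected range of 600 nM to 2400 nM in this measurement.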

Compound 4, half-maximal inhibitory concentration: 1400 nM
Compound 4: the middle estimate sits 1.2-fold (0.07 log units) below what was measured, and the stated range covers the measured number.
By their numbers in this assay, from the lowest: compounds 1, 3, 4 and 2 (each within the scatter of the next).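

Chloro in place of methoxy on an aromatic carbon, para to a large group, is the first measured change at this position, and in this assay it leaves the number level (a 1.1-fold higher number from compound 3 to compound 4 (0.03 log units; within the scatter)). The 4-chlorophenyl group also stands level with furan-2-yl (a 1.1-fold lower number from compound 2 to compound 4 (0.03 log units; within the scatter)) and with cyclopropyl (a 1.2-fold higher number from compound 1 to compound 4 (0.07 log units; within the scatter)) on the carbonyl carbon. No supporting measurement is available to explain these results. Going by these compounds, whether an amine or a carboxylic acid para to a large group would move the number beyond the scatter remains open.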